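The source may hold more compounds than are shown below. What is called first, only, known or untested is meant among the compounds shown, and "the series" means these compounds.

Three compounds have been measured in a functional assay on MCF7 cells (Homo sapiens) for cytotoxicity, read by MTT assay, with a stated time of 48 h; a higher number here means a weaker inhibitor, a lower number a stronger inhibitor:

Compound 1 `COc1ccc(/C=N/NC(=O)CSc2nnc(-c3ccncc3)o2)cc1` gives 17600 nM
Compound 2 `O=C(CSc1nnc(-c2ccncc2)o1)N/N=C/c1ccccc1O` gives 4750 nM
Compound 3 `O=C(CSc1nnc(-c2ccncc2)o1)N/N=C/c1ccc(Cl)cc1Cl` gives 27900 nM

Among these three numbers compound 1 stands second highest. Its gap to compound 3, a 1.6-fold higher number from compound 1 to compound 3 (0.20 log units; within the scatter), lies within the usual scatter, so the two cannot be told apart. Among the compounds with values here, its gap to compound 2, a 3.7-fold lower number from compound 1 to compound 2 (0.57 log units; beyond the scatter), goes beyond the scatter and is the only clear step in this set. Compound 4 `O=C(CSc1nnc(-c2ccncc2)o1)N/N=C/C=C/c1ccccc1` differs from compound 1 in one place: 2-phenylethenyl in place of 4-methoxyphenyl on a carbon with a double bond to nitrogen. Neither measured step covers this particular exchange. Within the data shown here, the one step that moved the number clearly, a 3.7-fold lower number from compound 1 to compound 2 (0.57 log units; beyond the scatter), brought in a 2-hydroxyphenyl, a group with a hydrogen-bond donor, which 2-phenylethenyl lacks; the step that brought in a group without such a donor, a 1.6-fold higher number from compound 1 to compound 3 (0.20 log units; within the scatter), stayed within the scatter. On this basis the expected step in this assay from compound 1 to compound 4 is a 1.2-fold lower number from compound 1 to compound 4 (0.07 log units; within the scatter), that is, no change beyond the scatter. Compound 4 is therefore estimated at 15000 nM, with a range from 5000 nM to 45000 nM.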

Compound 4, half-maximal inhibitory concentration: 10800 nM
Compound 4: the middle estimate sits 1.4-fold (0.14 log units) above what was measured; the measured number falls inside the stated range.
By their numbers in this assay, from the lowest: compound 2; then compounds 4, 1 and 3 (each within the scatter of the next, the first and the last beyond it).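

In this assay, putting 2-phenylethenyl on the carbon with a double bond to nitrogen gives a step that stays within the scatter (a 1.6-fold lower number from compound 1 to compound 4 (0.21 log units; within the scatter)), so this group cannot be told apart from 4-methoxyphenyl. It does separate from the other two groups at this position, with one step (a 2.6-fold lower number from compound 3 to compound 4 (0.41 log units; beyond the scatter)) and another (a 2.3-fold higher number from compound 2 to compound 4 (0.36 log units; beyond the scatter)) both beyond the scatter. Compound 2 now stands clearly lowest of all four, and the groups without a hydrogen-bond donor are not all alike, since compound 4 and compound 3 differ clearly while compound 1 matches each of them within the scatter.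

Nothing shown here explains these differences. Going by these compounds, whether the hydroxyl itself sets compound 2 apart remains open, and an aminophenyl or a plain phenyl group at this position would speak to that.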